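This account rests on a few compounds, and the source may have more. Where it says the series, first, only, none or still open, it means among the compounds named here.

Working notes on the series.

For the measured compounds named here, compound 2 `Cc1cc(N2CCC(N3CCCC3C)C2)ccc1NC(=O)C1CCOCC1` is the lowest of the two numbers so far in an assay on CHO cells for displacement of a labelled ligand from histamine receptor H3 (Macaca mulatta) (a higher number here means a weaker inhibitor, a lower number a stronger inhibitor), where compound 2 gives 6.8 nM. Going by the values given here, its nearest neighbour is compound 1 `Cc1cc(N2CCC(N3CCCC3C)C2)ccc1NC(=O)C1C(C)(C)C1(C)C`, which in this assay gives 37.3 nM; the one step between them, a 5.5-fold lower number from compound 1 to compound 2 (0.74 log units; beyond the scatter), concerns the group on the carbonyl carbon and not stereochemistry.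

Compound 3 `Cc1cc(N2CC[C@@H](N3CCC[C@@H]3C)C2)ccc1NC(=O)C1CCOCC1` differs from compound 2 only in drawn configuration: the two compounds have the same atoms and bonds; at least one stereo element is drawn with a configuration in one of them and without one in the other: 2 of 2 stereo elements differ; a stereocentre at a saturated ring carbon is drawn without a configuration in compound 2 and R in compound 3; a stereocentre at a saturated ring carbon is drawn without a configuration in compound 2 and S in compound 3. Among the compounds with values here, no measured step bears on such a change; the single step in hand does not involve it. A defined stereoisomer of a compound drawn without configuration is expected to come out at a similar or somewhat lower number, so the expected step is a 1.5-fold lower number from compound 2 to compound 3 (0.18 log units; within the scatter), which stays within the scatter.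

Compound 3 is therefore estimated at 4.5 nM in this assay, with a range from 1.5 nM to 12 nM.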

Compound 3, inhibition constant: 3.9 nM
The estimate for compound 3 lay 1.2-fold (0.06 log units) above the measured number; measured number inside the range.
By their numbers in this assay, from the lowest: compounds 3 and 2 (each within the scatter of the next); then compound 1.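

In this assay, for the compounds shown here, the first reading on stereochemistry is a 1.7-fold lower number from compound 2 to compound 3 (0.24 log units; within the scatter) and it stays within the scatter, so compound 3 with both stereocentres drawn and compound 2 without drawn configuration cannot be told apart. The earlier step concerned only the group on the carbonyl carbon, whereas here the oxan-4-yl group stays in place and the number remains in the same range. The comparison sets a defined stereoisomer against a compound of undrawn configuration, so it does not compare one defined stereoisomer with another: the fact that one of compounds 2 and 3 is drawn with a defined configuration and the other without, at the place where they differ

Going by these compounds, the standing of the other configurations at these two saturated ring carbons remains open, so the contribution of each stereocentre cannot be separated. Also open, on these data alone, is whether the configuration of compound 3 would give a similar number with an amine or a carboxylic acid in place of oxan-4-yl on the carbonyl carbon.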